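Removal of the para substituent in the nitro dienone series

This account rests on a few compounds, and the source may have more. Where it says the series, first, only, none or still open, it means among the compounds named here.

Compound 3 `O=C1/C(=C/c2ccc(Cl)cc2)CCC/C1=C\c1ccccc1[N+](=O)[O-]` has been measured in a physicochemical assay for lipophilicity (a lower number here means a more polar compound, a higher number a more lipophilic compound), where compound 3 gives 4.86. Two further members of the series share the same value at the digits shown: compound 1 `Cc1ccc(/C=C2\CCC/C(=C\c3ccccc3[N+](=O)[O-])C2=O)cc1` gives 4.86 and compound 2 `COc1ccc(/C=C2\CCC/C(=C\c3ccccc3[N+](=O)[O-])C2=O)cc1` gives 4.86. The three measured steps are all within the scatter: no change at the digits printed from compound 1 to compound 2 (within the scatter), no change at the digits printed from compound 1 to compound 3 (within the scatter) and no change at the digits printed from compound 2 to compound 3 (within the scatter). Compound 3 therefore stands level with compound 1 and compound 2, with no ordering among the three that the numbers support.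

Compound 4 `O=C1/C(=C/c2ccccc2)CCC/C1=C\c1ccccc1[N+](=O)[O-]` is not yet measured in this assay. The change from compound 3 is hydrogen in place of chloro on an aromatic carbon. Every measured step exchanges one substituent at that position for another, and none removes it; none therefore bears directly on the step to compound 4. With no measured change across methyl, methoxy and chloro, a step toward a lower value is estimated, of about a number 0.36 log units lower from compound 3 to compound 4 (beyond the scatter), which may fall within the scatter. Compound 4 is expected to give 4.5, in a range from 4 to 5.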

Compound 4, partition coefficient: 4.86
The estimate for compound 4 lay 0.36 log units below the measured number; low and high end bracket the measured number.
By their numbers in this assay, from the lowest: compounds 1, 2, 3 and 4 (each within the scatter of the next).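

In this assay, hydrogen in place of chloro gives no change at the digits printed from compound 3 to compound 4 (within the scatter) and hydrogen in place of methoxy gives no change at the digits printed from compound 2 to compound 4 (within the scatter); hydrogen in place of methyl likewise gives no change at the digits printed from compound 1 to compound 4 (within the scatter). The earlier steps shown here only exchanged one substituent for another, whereas these steps remove the substituent altogether, so hydrogen, methyl, methoxy and chloro on this aromatic carbon, para to a large group, cannot be told apart by this read-out. No evidence at hand explains why the four numbers coincide.

From the compounds shown here alone, it remains open whether an amine, a carboxylic acid or a longer chain at this position would separate from these four compounds. Also open, going by these compounds, is whether replacing the nitro group elsewhere on the shared core would move the number.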